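The compounds below may be only part of what the source reports. "The series", "measured", "known", "first", "only" and "open" are said of these compounds alone.

Compounds measured so far:
Compound 1, `CCCCCCCCCCCCC(CC)C(=O)Nc1c(OC)cc(OC)cc1OC`, gives 52 nM in an assay on microsomes from intestine for inhibition of acyl-CoA:cholesterol acyltransferase (Oryctolagus cuniculus); a higher number here means a weaker inhibitor, a lower number a stronger inhibitor.
Compound 2, `CCCCCCCCCCC(C)(C)C(=O)Nc1c(C)cccc1C`, gives 1300 nM in this assay.
Compound 3, `CCCCCCCCCCC(C)(C)C(=O)Nc1c(C)cccc1OC`, gives 210 nM in this assay.

Compound 3 stands second highest of the three numbers: compound 1 sits a clear way below it, and compound 2 a clear way above it. For the measured compounds named here, the only single-point step among the measured compounds is a 6.2-fold lower number from compound 2 to compound 3 (0.79 log units; beyond the scatter), in which a methoxy replaced a methyl on the aromatic ring.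

Compound 4, `CCCCCCCCCCC(C)(C)C(=O)Nc1c(C)cccc1OCC`, differs from compound 3 by methyl in place of hydrogen on a saturated chain carbon bound to an oxygen on an aromatic ring, that is, methoxy to ethoxy. Going by the values given here, no measured step alters this chain on the oxygen; the step from compound 2 to compound 3 concerns the group on the ring carbon itself, and so bears only loosely on it. Compound 1 shows that further methoxy groups on the ring go with a lower number, but it says nothing about lengthening the chain. The account therefore expects compound 4 to stay near compound 3, with a step of a 1.3-fold lower number from compound 3 to compound 4 (0.12 log units; within the scatter) that is not expected to go beyond the scatter. Compound 4 is thus estimated at 160 nM, within a range of 50 nM to 500 nM.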

Compound 4, half-maximal inhibitory concentration: 180 nM
Compound 4: the middle estimate sits 1.1-fold (0.05 log units) below what was measured; the range from low to high includes it.
By their numbers in this assay, from the lowest: compound 1; then compounds 4 and 3 (each within the scatter of the next); then compound 2.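

In this assay, extending methoxy to ethoxy gives a 1.2-fold lower number from compound 3 to compound 4 (0.07 log units; within the scatter), so the chain on this oxygen takes one more methyl with no change that can be told from the scatter. The lower number reached when an oxygen group replaces the methyl on the aromatic carbon also holds for ethoxy, with a 7.2-fold lower number from compound 2 to compound 4 (0.86 log units; beyond the scatter), so among the compounds shown it is not confined to methoxy. Nothing given here bears on the reason for either result.

On these data alone, it remains open whether a longer chain on this oxygen, such as butoxy, or a branched one, such as isopropoxy, would also stay close to compound 3. Also open, as far as these compounds go, is what a hydroxyl group or a fluorine atom would give on the same aromatic carbon.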